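A few compounds are considered here, and "the series" means these few. Any claim that something is new, unique, unknown or untested is made for them only; others in the source may bear on it.

Compound 1 `CO[C@@H]1C/C=C(\C)C(=O)N(C)[C@@H](C(C)C)C(=O)N[C@H](Cc2ccccc2)C(=O)N[C@@H](C(C)C)C(=O)O[C@H](c2ccccc2)[C@H](C)/C=C/C=C/1C` is a large ring-shaped molecule. In a functional assay on HCT-116 cells (Homo sapiens) for antiproliferative activity, read by MTT assay, with a stated time of 72 h (a lower number here means a stronger inhibitor, a higher number a weaker inhibitor), compound 1 gives > 100 nM, which is a limit of the assay. Compound 2 `CO[C@@H]1C/C=C(\C)C(=O)N(C)[C@@H](C(C)C)C(=O)N[C@H](Cc2ccccc2)C(=O)N[C@@H](C(C)C)C(=O)O[C@H](c2ccccc2)C/C=C/C=C/1C` carries hydrogen in place of methyl on a saturated ring carbon, and compound 2 gives > 100 nM, again a limit. Because (the limit of > 100 nM in this assay, at which 2 of the 2 values shown sit), the step that the two limits leave unreadable from compound 1 to compound 2 cannot be read in size. Compound 3 `CO[C@@H]1C/C=C(\C)C(=O)N(C)[C@@H](C(C)C)C(=O)N[C@H](Cc2ccc(O)cc2)C(=O)N[C@@H](C(C)C)C(=O)O[C@H](c2ccccc2)[C@H](C)/C=C/C=C/1C` differs from compound 1 by hydroxy in place of hydrogen on an aromatic carbon. For the measured compounds named here, no measured step touches this change; the only measured step alters another part of the shared core and has no readable size. The expected outcome for compound 3 is therefore no movement beyond the scatter, with a step that the limit leaves unreadable from compound 1 to compound 3. Compound 3 is estimated at 300 nM in this assay, within a range from 100 nM to 1500 nM.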

Compound 3, half-maximal inhibitory concentration: 59.7 nM
Beside the measured number, compound 3's estimate is 5.0-fold (0.70 log units) above it; measured number outside the range, below it.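

In this assay, for the compounds shown here, compound 3 gives 59.7 nM, the first number that is not a limit of the assay. Changing benzyl to 4-hydroxybenzyl, which puts a hydroxy group in place of a hydrogen on the aromatic ring, gives an at least 1.6-fold lower number from compound 1 to compound 3 (0.22 log units; that floor lies within the scatter). So this place on the molecule can take a hydroxy group without loss of activity in these cells, but the real size of the gain cannot be fixed, because compound 1 has no exact number: the limit of > 100 nM in this assay, at which 2 of the 3 values shown sit.

Going by these compounds, whether a methoxy group or an amine at this same place would give a lower or a higher number stays open. On these data alone, it is also open whether the hydroxy group would have a similar effect on the core of compound 2.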